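Trading a ring tail for a chain amine

The source may hold more compounds than are shown below. What is called first, only, known or untested is meant among the compounds shown, and "the series" means these compounds.

In an assay on isolated protein for displacement of a labelled ligand from Apoptosis regulator Bcl-2 (Homo sapiens), with a stated time of 15 min (on this read-out higher numbers stand for weaker inhibition and lower numbers for stronger inhibition), compound 1 `CC1(C)CCC(CN2CCN(c3ccc(C(=O)NS(=O)(=O)c4ccc(NCC5CCOCC5)c([N+](=O)[O-])c4)c(Oc4cnc5[nH]ccc5c4)c3)CC2)=C(c2ccc(Cl)cc2C(F)(F)F)C1` gives 0.86 nM. Compound 2 `CC1(C)CCC(CN2CCN(c3ccc(C(=O)NS(=O)(=O)c4ccc(NCC5CCOCC5)c([N+](=O)[O-])c4)c(Oc4cnc5[nH]ccc5c4)c3)CC2)=C(c2ccc(C(F)(F)F)cc2)C1` gives 1.5 nM, and compound 3 `CC1(C)CCC(CN2CCN(c3ccc(C(=O)NS(=O)(=O)c4ccc(NCC5CCOCC5)c([N+](=O)[O-])c4)c(Oc4cnc5[nH]ccc5c4)c3)CC2)=C(c2ccccc2C(F)(F)F)C1` gives 1.7 nM. Compound 2 stands second highest of these three numbers; its nearest neighbour is compound 3, with a 1.1-fold higher number from compound 2 to compound 3 (0.05 log units; within the scatter), and its furthest is compound 1, with a 1.7-fold higher number from compound 1 to compound 2 (0.24 log units; within the scatter). The remaining step, a 2.0-fold higher number from compound 1 to compound 3 (0.30 log units; within the scatter), also stays within the scatter. All three measured steps alter only the aryl group on the double-bonded ring carbon, and none of them moves the read-out beyond the scatter. Compound 4 `CCN(CC)CCCNc1ccc(S(=O)(=O)NC(=O)c2ccc(N3CCN(CC4=C(c5ccc(C(F)(F)F)cc5)CC(C)(C)CC4)CC3)cc2Oc2cnc3[nH]ccc3c2)cc1[N+](=O)[O-]` differs from compound 2 at a different place: 2-(diethylamino)ethyl in place of oxan-4-yl on a saturated chain carbon bound to a nitrogen on an aromatic ring. For the measured compounds named here, no measured step touches that chain, so nothing among the known numbers bears directly on this change; the only guidance is that the shared core has so far tolerated variation without a step beyond the scatter. On that basis the expected step is no change at the digits printed from compound 2 to compound 4 (within the scatter), none beyond the scatter. Compound 4 is accordingly estimated at 1.5 nM, within 0.5 nM to 4.5 nM.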

Compound 4, half-maximal inhibitory concentration: 0.3 nM
Compound 4: middle estimate off by 5.0-fold (0.70 log units), on the high side, outside the stated range (below it).
By their numbers in this assay, from the lowest: compound 4; then compounds 1, 2 and 3 (each within the scatter of the next).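

In this assay, the chain on the nitrogen bound to the aromatic ring proves to be a place where a change moves the read-out: there is a 5.0-fold lower number from compound 2 to compound 4 (0.70 log units; beyond the scatter), whereas all three steps at the aryl group on the double-bonded ring carbon stayed within the scatter. The exchange of (oxan-4-yl)methyl for 3-(diethylamino)propyl gives up a ring and an oxygen for an open chain carrying a nitrogen, and the inhibition grows stronger. Nothing available here explains why the number falls.

The compounds shown leave open whether the step belongs to the amine nitrogen or to the open chain itself, a question on which a plain pentyl chain or a piperidine at the chain end would bear. As far as these compounds go, whether the step carries over to the aryl group of compound 1 also stays open.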